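This account rests on a few compounds, and the source may have more. Where it says the series, first, only, none or still open, it means among the compounds named here.

Measured in a functional assay on the whole organism (Cavia porcellus) with Rattus norvegicus as the target; on this read-out higher numbers stand for an effect only at larger amounts of compound and lower numbers for an effect already at smaller amounts:
- Compound 1 `CC1=C(C)n2c(noc2=O)[C@](O)(c2ccc(Cl)cc2)S1` gives 705000000 nM
- Compound 2 `CC1=CS[C@@](O)(c2cccc(C)c2)c2noc(=O)n21` gives 719000000 nM
- Compound 3 `CC1=CS[C@@](O)(c2cccc([N+](=O)[O-])c2)c2noc(=O)n21` gives 568000000 nM

Compound 3 (568000000 nM) lies within the scatter of both compound 1 and compound 2, so the three values cannot be ranked. Compound 4 `CC1=CS[C@@](O)(c2cccc(C(F)(F)F)c2)c2noc(=O)n21` carries trifluoromethyl in place of nitro on an aromatic carbon. Among the compounds with values here, the one measured step that bears on this change, nitro in place of methyl on an aromatic carbon (a 1.3-fold lower number from compound 2 to compound 3 (0.10 log units; within the scatter)), stays within the scatter. No change beyond the scatter is therefore expected in this assay. The expected step (a 1.1-fold higher number from compound 3 to compound 4 (0.06 log units; within the scatter)) is correspondingly small. Compound 4 is estimated at 650000000 nM (expected range 350000000 nM to 1100000000 nM).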

Compound 4, half-maximal effective concentration: 461000000 nM
Compound 4: middle estimate off by 1.4-fold (0.15 log units), on the high side, within the range that was stated.
By their numbers in this assay, from the lowest: compounds 4, 3, 1 and 2 (each within the scatter of the next).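

In this assay, trifluoromethyl on this aromatic carbon, meta to a large group, gives a 1.2-fold lower number from compound 3 to compound 4 (0.09 log units; within the scatter) and a 1.6-fold lower number from compound 2 to compound 4 (0.19 log units; within the scatter), so both steps stay within the scatter. A third group at this place, one with no hydrogen-bond acceptors where nitro has them, thus leaves the read-out where methyl and nitro put it. Going by these compounds, whether an amine or a carboxylic acid at this place would move the number beyond the scatter remains open. Nothing available explains why these three groups give such similar values.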